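The source may report more compounds than this note shows. Statements on the series, on what has been measured and on what is new or still open speak of the compounds shown alone.

Compound 1 `CN(C)CCCN(/N=N/c1ccc([N+](=O)[O-])cc1)c1ccccc1` gives 20000 nM
Compound 2 `CN(C)CCCN(/N=N/c1cccc([N+](=O)[O-])c1)c1ccccc1` gives 14000 nM
Compound 3 `CN(C)CCCN(/N=N/c1ccccc1)c1cccc(C(F)(F)F)c1` gives 14000 nM

In an ADME assay on MT4 cells (Homo sapiens) for cytotoxicity, read by MTT assay, with a stated time of 96 h (on this read-out higher numbers stand for lower toxicity in this test and lower numbers for higher toxicity in this test), compound 2 and compound 3 stand level at 14000 nM and compound 1 at 20000 nM lies within the scatter of both. Compound 4 `CN(C)CCCN(/N=N/c1ccccc1)c1ccccc1` is not yet measured. It differs from compound 3 by hydrogen in place of trifluoromethyl on an aromatic carbon with hydrogen in place of trifluoromethyl on an aromatic carbon. For the measured compounds named here, no measured pair differs in one place only, so the sole guide is the narrow spread of these three values. No step beyond the scatter is expected in this assay for this change. The expected 1.2-fold higher number from compound 3 to compound 4 (0.08 log units; within the scatter) stays within the scatter. Compound 4 is estimated at 17000 nM (range 8000 nM to 40000 nM).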

Compound 4, half-maximal cytotoxic concentration: 33000 nM
Compound 4: the middle estimate sits 1.9-fold (0.29 log units) below what was measured; low and high end bracket the measured number.
By their numbers in this assay, from the lowest: compounds 2, 3, 1 and 4 (each within the scatter of the next, the first and the last beyond it).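

In this assay, hydrogen in place of trifluoromethyl on this aromatic carbon, meta to a large group, gives a step beyond the scatter (a 2.4-fold higher number from compound 3 to compound 4 (0.37 log units; beyond the scatter)), and hydrogen in place of nitro gives one of the same size (a 2.4-fold higher number from compound 2 to compound 4 (0.37 log units; beyond the scatter)). The nitro of compound 1 goes against this pattern (a 1.7-fold higher number from compound 1 to compound 4 (0.22 log units; within the scatter)), so not every nitro placement separates from hydrogen. The data give no explanation for these steps. From the compounds shown here alone, whether an amine or a methoxy group on this aromatic carbon would track with trifluoromethyl or with hydrogen remains open.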